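This account rests on a few compounds, and the source may have more. Where it says the series, first, only, none or still open, it means among the compounds named here.

Going by the values given here, compound 1 `O=C(CN1CCN(c2ccc(F)cc2)CC1)Nc1nc2c(s1)CCCCC2` is the one compound in this small set with a number: in an assay on isolated protein for inhibition of long-chain fatty acid transport protein 1 (Mus musculus), read by scintillation counting, with a stated time of 20 min (a lower number here means a stronger inhibitor, a higher number a weaker inhibitor), compound 1 gives 2000 nM. Compound 2 `Cc1ccc(N2CCN(CC(=O)Nc3nc4c(s3)CCCC4)CC2)cc1` returns only a limit in this assay, > 10000 nM, and that figure is a boundary of the measurement rather than a value; it sits at the limit of > 10000 nM in this assay, at which 1 of the 2 values shown sits. Compound 3 `O=C(CN1CCN(c2ccccn2)CC1)Nc1nc2c(s1)CCCC2` has not yet been measured in this assay. It differs from compound 2 in one place: pyridin-2-yl in place of 4-methylphenyl on an amine nitrogen in a ring. Among the compounds with values here, no step between measured compounds is available, so the size of this change cannot be read from any pair; the two values shown tell only that compound 1 has a number and compound 2 does not. The expected step of an at least 1.4-fold lower number from compound 2 to compound 3 (0.15 log units; that floor lies within the scatter) is a modest move toward a stronger inhibitor, though not clearly beyond the scatter. Compound 3 is therefore estimated at 7000 nM in this assay, with a range from 2000 nM to 25000 nM.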

Compound 3, half-maximal inhibitory concentration: 4900 nM
The estimate for compound 3 lay 1.4-fold (0.15 log units) above the measured number, within the range that was stated.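

Pyridin-2-yl in place of 4-methylphenyl on the amine nitrogen in the ring gives the first readable step at this place in this assay, an at least 2.0-fold lower number from compound 2 to compound 3 (0.30 log units; that floor lies within the scatter), whereas the earlier compounds offered no step at all. The value for compound 2 is a limit: the limit of > 10000 nM in this assay, at which 1 of the 3 values shown sits. The step is therefore a floor on the change and not its size, and what it does show is that the swap turns a limit into a number, with a group that counts one hydrogen-bond acceptor replacing one that counts none.

The compounds shown leave open whether the gain follows the ring nitrogen of pyridin-2-yl or the loss of the methyl, which a plain phenyl at this place would separate. They also leave open how a pyridin-3-yl or a pyrimidin-2-yl would read here.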